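The source may report more compounds than this note shows. Statements on the series, on what has been measured and on what is new or still open speak of the compounds shown alone.

Series of compound 1 `O=c1ccc(-c2ccccc2)nn1CCCCNC(=S)Nc1ccccc1`, compound 2 `C=CCNC(=S)NCCCCn1nc(-c2ccccc2)ccc1=O` and compound 3 `C/N=C(/NC#N)N(C)CCCCn1nc(-c2ccccc2)ccc1=O`, all sharing the same core and chain. In a functional assay on the whole organism with Rattus norvegicus as the target, at a dose of 100 mg/kg (a higher number here means more inhibition at the dose given (going by the name of the read-out), a lower number less inhibition), compound 1 gives 38.4%, compound 2 gives 27.1% and compound 3 gives 27%. Compound 3 thus holds the lowest of the three numbers, though its gap to compound 2 lies within the scatter; only the gap to compound 1 is beyond it.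

Compound 4 `N#CNC(=N)NCCCCn1nc(-c2ccccc2)ccc1=O` is not yet measured. The change: a group of 6 heavy atoms (2 carbon, 4 nitrogen; no ring) in place of a group of 8 heavy atoms (4 carbon, 4 nitrogen; no ring), on a saturated chain carbon, four bonds along the chain from an aromatic nitrogen.

Measured steps: a number 11.3 percentage points lower from compound 1 to compound 2 (beyond the scatter); a number 0.1 percentage points lower from compound 2 to compound 3 (within the scatter). The second step is the nearer analogue, as it also swaps the group on the chain carbon four bonds from the aromatic nitrogen, and it moved nothing. A step of no change at the digits printed from compound 3 to compound 4 (within the scatter) is therefore expected, none beyond the scatter. For compound 4 the expected value is 27%, range 15% to 40%.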

Compound 4, a percentage reported as inhibition, in the whole organism at one dose (the size of the read-out at that dose, not a potency): 61.2%
The estimate for compound 4 lay 34.2 percentage points below the measured number, and the stated range ends below it.
By their numbers in this assay, from the lowest: compounds 3 and 2 (each within the scatter of the next); then compound 1; then compound 4.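

At the saturated chain carbon, four bonds along the chain from an aromatic nitrogen, the group is not indifferent: the swap that moved nothing before now gives a number 34.2 percentage points higher from compound 3 to compound 4 (beyond the scatter), with 3 hydrogen-bond donors entering where 1 leaves. The same group also exceeds the other two chain ends, with a number 34.1 percentage points higher from compound 2 to compound 4 (beyond the scatter) and a number 22.8 percentage points higher from compound 1 to compound 4 (beyond the scatter), which puts compound 4 above all three. No measurement at hand accounts for this gain.

The change from compound 3 to compound 4 alters group size and donor count together, and these compounds do not separate the two. From the compounds shown here alone, whether a longer chain, or a carboxylic acid in place of the nitrile, retains this level stays open.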